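This account rests on a few compounds, and the source may have more. Where it says the series, first, only, none or still open, it means among the compounds named here.

Compound 1 `CN1CCN(CCCN(c2nc3cc(F)c(F)cc3[nH]2)[C@@H]2CC[C@]3(c4cccc(C#N)c4)C[C@@H]3C2)CC1` gives 8.4 nM in an assay on isolated protein for binding affinity to melanin-concentrating hormone receptor 1 (Homo sapiens); a lower number here means a stronger inhibitor, a higher number a weaker inhibitor.
Compound 2 `CN1CCN(CCCN(c2nc3cc(F)c(F)cc3[nH]2)[C@@H]2CC[C@]3(c4cccc(C=O)c4)C[C@@H]3C2)CC1` gives 16.3 nM in this assay.
Compound 3 `CN1CCN(CCCN(c2nc3cc(F)c(F)cc3[nH]2)[C@@H]2CC[C@]3(c4cccc(CN5CCC[C@H]5CO)c4)C[C@@H]3C2)CC1` gives 3000 nM in this assay.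

Of these three, compound 3 stands at the highest number, the weakest binding: the step of a 360-fold higher number from compound 1 to compound 3 (2.55 log units; beyond the scatter) and the step of a 180-fold higher number from compound 2 to compound 3 (2.26 log units; beyond the scatter) are both large, whereas a 1.9-fold higher number from compound 1 to compound 2 (0.29 log units; within the scatter) is small. Compound 4 `CN1CCN(CCCN(c2nc3cc(F)c(F)cc3[nH]2)[C@@H]2CC[C@]3(c4cccc(CN5CCCCC5)c4)C[C@@H]3C2)CC1` differs from compound 3 in one place: piperidin-1-yl in place of 2-(hydroxymethyl)pyrrolidin-1-yl on a saturated chain carbon bound to an aromatic carbon. Among the measured compounds shown here, no measured step covers this exact change. For the measured compounds named here, the two large steps show only that the number rose steeply when a ring of this kind, on a saturated chain carbon bound to an aromatic carbon, replaced cyano or formyl. Because compound 3 already carries such a ring and gives 3000 nM, compound 4 is expected to stay near it, perhaps somewhat lower: a 2.0-fold lower number from compound 3 to compound 4 (0.30 log units; within the scatter). Compound 4 is therefore estimated at 1500 nM, within 300 nM to 6000 nM.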

Compound 4, inhibition constant: 405 nM
Compound 4: the middle estimate sits 3.7-fold (0.57 log units) above what was measured; low and high end bracket the measured number.
By their numbers in this assay, from the lowest: compounds 1 and 2 (each within the scatter of the next); then compound 4; then compound 3.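

Rings on this saturated chain carbon are not interchangeable: piperidin-1-yl in place of 2-(hydroxymethyl)pyrrolidin-1-yl recovers part of the lost binding (a 7.4-fold lower number from compound 3 to compound 4 (0.87 log units; beyond the scatter)). The recovery is only partial, as the piperidine compound still binds more weakly than the formyl and cyano compounds (a 25-fold higher number from compound 2 to compound 4 (1.40 log units; beyond the scatter); a 48-fold higher number from compound 1 to compound 4 (1.68 log units; beyond the scatter)). No supporting data explain these differences.

This swap changes ring size and removes the hydroxymethyl group together, so the two changes cannot be separated here. Plain pyrrolidin-1-yl, without hydroxymethyl, would help to tell them apart.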